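The source may report more compounds than this note shows. Statements on the series, on what has been measured and on what is new or still open speak of the compounds shown alone.

In a functional assay on PC-3 cells (Homo sapiens) for cytotoxicity, read by MTT assay, with a stated time of 72 h (a lower number here means a stronger inhibitor, a higher number a weaker inhibitor), compound 1 (`O=C(/C=C/c1ccc([N+](=O)[O-])cc1)Nc1cc2c(Nc3ccc(F)c(Cl)c3)ncnc2cc1O[C@H]1CCOC1`) gives 22800 nM, compound 2 (`O=C(/C=C/c1cccc(Cl)c1Cl)Nc1cc2c(Nc3ccc(F)c(Cl)c3)ncnc2cc1O[C@H]1CCOC1`) gives 27500 nM, and compound 3 (`COc1ccc(/C=C/C(=O)Nc2cc3c(Nc4ccc(F)c(Cl)c4)ncnc3cc2O[C@H]2CCOC2)c(OC)c1`) gives 2760 nM, the lowest number of the three. Compound 4 (`N#Cc1ccc(/C=C/C(=O)Nc2cc3c(Nc4ccc(F)c(Cl)c4)ncnc3cc2O[C@H]2CCOC2)cc1`) departs from compound 3 by one change: 4-cyanophenyl in place of 2,4-dimethoxyphenyl on a double-bonded chain carbon bound to a double-bonded chain carbon. Going by the values given here, two measured steps bear on it, an 8.3-fold lower number from compound 1 to compound 3 (0.92 log units; beyond the scatter) and a 10-fold lower number from compound 2 to compound 3 (1.00 log units; beyond the scatter), and both bring in the 2,4-dimethoxyphenyl that compound 4 gives up. The third step, a 1.2-fold higher number from compound 1 to compound 2 (0.08 log units; within the scatter), stays within the scatter. Among the compounds with values here, no 4-cyanophenyl compound has been measured, so a rise of somewhat smaller size in this assay is expected, namely a 5.1-fold higher number from compound 3 to compound 4 (0.71 log units; beyond the scatter). For compound 4 the estimated value is 14000 nM, within an expected range of 4500 nM to 40000 nM.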

Compound 4, half-maximal inhibitory concentration: 36600 nM
Estimate against measurement, compound 4: 2.6-fold (0.42 log units) below; the measured number falls inside the stated range.
By their numbers in this assay, from the lowest: compound 3; then compounds 1, 2 and 4 (each within the scatter of the next).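

In this assay, the 4-cyanophenyl gives up what 2,4-dimethoxyphenyl had gained at this position, with a 13-fold higher number from compound 3 to compound 4 (1.12 log units; beyond the scatter). Cyano in place of nitro makes no difference beyond the scatter, with a 1.6-fold higher number from compound 1 to compound 4 (0.21 log units; within the scatter), and 4-cyanophenyl in place of 2,3-dichlorophenyl reads the same, with a 1.3-fold higher number from compound 2 to compound 4 (0.12 log units; within the scatter), so among these four compounds only the 2,4-dimethoxyphenyl of compound 3 stands apart. Nothing available accounts for this difference. The compounds shown leave open whether a single methoxy group would suffice, and how an amine or a hydroxyl group on this phenyl ring would read.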